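Adding fluoro to the methyl compound of the series

The compounds below may be only part of what the source reports. "The series", "measured", "known", "first", "only" and "open" are said of these compounds alone.

Compound 1 `O=C1Nc2c(ccc(F)c2F)C1(c1ccc(O)cc1)C1CCCCCC1` gives 1.2 nM in a functional assay on MCF7 cells (Homo sapiens) for cytotoxicity, read by WST assay, with a stated time of 72 h; a lower number here means a stronger inhibitor, a higher number a weaker inhibitor. Compound 2 `Cc1cccc2c1NC(=O)C2(c1ccc(O)cc1)C1CCCCCC1` reads > 1000 nM in this assay, and this is a limit of the assay, not a number. Compound 2 therefore offers no exact starting point for a step.

Compound 3 `Cc1c(F)ccc2c1NC(=O)C2(c1ccc(O)cc1)C1CCCCCC1` differs from compound 2 by fluoro in place of hydrogen on an aromatic carbon, ortho to a methyl group. The expectation rests on compound 1, which carries fluoro on the shared core and gives 1.2 nM. The expected step of an at least 10-fold lower number from compound 2 to compound 3 (1.00 log units; beyond the scatter) in this assay is large and runs towards stronger inhibition, though a reading at the limit again remains possible. For compound 3 the estimated value is 100 nM, with an expected range of 3 nM to 3000 nM.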

Compound 3, half-maximal inhibitory concentration: 20 nM
Beside the measured number, compound 3's estimate is 5.0-fold (0.70 log units) above it; low and high end bracket the measured number.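

In this assay, fluoro in place of hydrogen on an aromatic carbon, ortho to a methyl group, gives an at least 50-fold lower number from compound 2 to compound 3 (1.69 log units; beyond the scatter), so this position turns a compound read only at a limit into one with an exact value. Methyl in place of fluoro on an aromatic carbon gives a 17-fold higher number from compound 1 to compound 3 (1.22 log units; beyond the scatter), so adding fluoro does not close the gap to compound 1 while the methyl group remains. The first step has only a bound on its size because compound 2 stands at a limit, not at a number: the limit of > 1000 nM in this assay, at which 1 of the 3 values shown sits.

Going by these compounds, whether chloro, methoxy or an amine at this position would give a similar step remains open. Also open, on these data alone, is whether fluoro here gives the same step on a core that carries ethyl in place of the methyl group.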